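A few compounds are considered here, and "the series" means these few. Any claim that something is new, unique, unknown or untested is made for them only; others in the source may bear on it.

Cytotoxicity across the series is followed in an ADME assay on HEL cells (Homo sapiens) for cytotoxicity, with a stated time of 3 days; a lower number here means that less compound is tolerated, a higher number that more compound is tolerated. Compound 1 `Cc1cc(-n2cccc2)cn2c(CSCc3ccccc3)cnc12` gives 20 ug/mL. For the measured compounds named here, compound 2 `Cc1cc(-c2ccsc2)c2ncc(CSCc3ccccc3)n2c1` gives 100 ug/mL, the higher of the two numbers so far; the gap to compound 1 lies beyond the usual scatter. Compound 3 `Cc1cc(N2CCCC2)c2ncc(CSCc3ccccc3)n2c1` is not yet measured; it differs from compound 2 by pyrrolidin-1-yl in place of thiophen-3-yl on an aromatic carbon. Going by the values given here, no measured pair isolates this change, so the expected step of a 1.4-fold lower number from compound 2 to compound 3 (0.15 log units; within the scatter) is set at none beyond the scatter. Compound 3 is therefore estimated at 70 ug/mL, with a range from 20 ug/mL to 100 ug/mL.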

Compound 3, minimum cytotoxic concentration: >= 20 ug/mL
Compound 3: no number, only a limit (the forecaster's own chance of this, stated with the estimate: 30%); the middle value is on the limit's open side.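

No step from compound 2 to compound 3 can be read, because compound 3 carries only a limit: the limit of >= 20 ug/mL in this assay, at which 1 of the 3 values shown sits.

The compounds shown leave open how pyrrolidin-1-yl in place of thiophen-3-yl on an aromatic carbon alters the number in this assay.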